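The source may hold more compounds than are shown below. What is called first, only, known or untested is meant among the compounds shown, and "the series" means these compounds.

Compound 1 `O=C1C(=Cc2ccc(O)cc2)C(=O)N(c2ccc(Cl)cc2)N1c1ccc(Cl)cc1` and compound 2 `O=C1C(=Cc2ccc(Br)cc2)C(=O)N(c2ccc(Cl)cc2)N1c1ccc(Cl)cc1` share one core with a para-substituted arylidene group, and both gave numbers in a functional assay on ECa-109 cells (Homo sapiens) for cytotoxicity, read by MTT assay, with a stated time of 72 h; a lower number here means a stronger inhibitor, a higher number a weaker inhibitor. Compound 1 gives 34200 nM and compound 2 gives 12300 nM, the move between them being a 2.8-fold lower number from compound 1 to compound 2 (0.44 log units; beyond the scatter). Compound 3 `COc1ccc(C=C2C(=O)N(c3ccc(Cl)cc3)N(c3ccc(Cl)cc3)C2=O)cc1` returned only the assay limit of > 128000 nM in this assay, so no number is known for it. Both steps into compound 3 are therefore bounds rather than measurements: an at least 3.7-fold higher number from compound 1 to compound 3 (0.57 log units; beyond the scatter) and an at least 10-fold higher number from compound 2 to compound 3 (1.01 log units; beyond the scatter), each pointing toward a weaker inhibitor.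

Compound 4 `COc1ccc(C=C2C(=O)N(c3ccc(Cl)cc3)N(c3ccc(Cl)cc3)C2=O)cc1OC` differs from compound 3 by methoxy in place of hydrogen on an aromatic carbon. For the measured compounds named here, no measured step in this set adds a second methoxy group, so the only guides are the two upward steps into compound 3 and the fact that compound 3 already sits at the limit of > 128000 nM in this assay, at which 1 of the 3 values shown sits. Compound 4 is thus expected to return a limit again rather than a number. Should a number appear, the step expected is a step that the limit leaves unreadable from compound 3 to compound 4. Compound 4 is estimated at 130000 nM, within a range from 50000 nM to 350000 nM.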

Compound 4, half-maximal inhibitory concentration: > 128000 nM
Compound 4: a limit, no number (the forecaster's own chance of this, stated with the estimate: 70%); the middle value is on the limit's open side.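

Adding a methoxy on the aromatic carbon ortho to a methoxy group does not bring a number back. In this assay compound 4 gives only a limit, > 128000 nM, and the step between compound 3 and compound 4 cannot be read, both ends being limits. Set against the two compounds with numbers, the 3,4-dimethoxyphenyl group gives an at least 10-fold higher number from compound 2 to compound 4 (1.01 log units; beyond the scatter) and an at least 3.7-fold higher number from compound 1 to compound 4 (0.57 log units; beyond the scatter), so both methoxy compounds now stand apart from the hydroxy and bromo compounds: the limit of > 128000 nM in this assay, at which 2 of the 4 values shown sit.

The compounds shown leave open how far beyond the limit compound 3 and compound 4 lie, and so whether the second methoxy changes anything at all. They also leave open how an amine or a carboxylic acid would read in place of the bromo of compound 2.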